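The compounds below may be only part of what the source reports. "The series", "measured", "known", "first", "only" and "open" are said of these compounds alone.

Compound 1 `O=S(=O)(/C=C/c1ccc(Cl)c(Cl)c1)Cc1ccc(Nc2ncnc3ccc(Br)cc23)cc1`: in a functional assay on OVCAR-8 cells (Homo sapiens) (a lower number here means a stronger inhibitor of growth, a higher number a weaker inhibitor of growth), compound 1 gives 100 nM.
Compound 2 `O=S(=O)(/C=C/c1ccc(Br)cc1)Cc1ccc(Nc2ncnc3ccc(Br)cc23)cc1`: in this assay compound 2 gives 2000 nM.
Compound 3 `O=S(=O)(/C=C/c1ccc(O)cc1)Cc1ccc(Nc2ncnc3ccc(Br)cc23)cc1`: in this assay compound 3 gives > 100000 nM, which is a limit of the assay and not a number.

Compound 3 thus stands as the weakest of the three, sitting at the limit of > 100000 nM in this assay, at which 1 of the 3 values shown sits. Compound 4 `O=S(=O)(/C=C/c1ccc(F)cc1F)Cc1ccc(Nc2ncnc3ccc(Br)cc23)cc1` differs from compound 3 by 2,4-difluorophenyl in place of 4-hydroxyphenyl on a double-bonded chain carbon bound to a double-bonded chain carbon. Within the data shown here, two measured steps bear on this change: an at least 50-fold higher number from compound 2 to compound 3 (1.69 log units; beyond the scatter) and an at least 1000-fold higher number from compound 1 to compound 3 (3.00 log units; beyond the scatter), both large and both running toward the hydroxy compound. Reversing that direction, a large fall in the number is expected for compound 4 in this assay, though a 20-fold higher number from compound 1 to compound 2 (1.30 log units; beyond the scatter) shows that not every halogenated phenyl reaches the level of compound 1. The expected step is an at least 100-fold lower number from compound 3 to compound 4 (2.00 log units; beyond the scatter). Compound 4 is estimated at 1000 nM, between 100 nM and 20000 nM.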

Compound 4, concentration for 50% growth inhibition: 100000 nM
Beside the measured number, compound 4's estimate is 100-fold (2.00 log units) below it; measured number above the stated range.
By their numbers in this assay, from the lowest: compound 1; then compound 2; then compound 4.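

Removing the hydroxy group in favour of halogens does not by itself restore growth inhibition at this place in this assay: the change gives a number no higher from compound 3 to compound 4 (the limit leaves the size open), and the 2,4-difluorophenyl compound lags both other halogenated compounds, with a 50-fold higher number from compound 2 to compound 4 (1.70 log units; beyond the scatter) and a 1000-fold higher number from compound 1 to compound 4 (3.00 log units; beyond the scatter). The size of the step from compound 3 cannot be read, since compound 3 holds only a limit of the assay: the limit of > 100000 nM in this assay, at which 1 of the 4 values shown sits. Still open, as far as these compounds go, is whether 3,4-difluorophenyl would track compound 1 or compound 4, and how 4-aminophenyl would fare at this place.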